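Swapping the aryl group of a histamine guanidine analogue

A few compounds are considered here, and "the series" means these few. Any claim that something is new, unique, unknown or untested is made for them only; others in the source may bear on it.

Compound 1 `Cc1ccc(C(CC/N=C(\N)NCCCc2c[nH]cn2)c2ccccn2)cc1` gives 7.15 in a functional assay on muscle tissue for agonist activity at histamine H2 receptor (Cavia porcellus); a higher number here means a more potent compound, by a factor of ten per unit of this negative logarithm, a lower number a less potent compound.
Compound 2 `N=C(NCCCc1c[nH]cn1)NCCC(c1ccc(Br)cc1)c1ccccn1` gives 6.97 in this assay.

Going by the values given here, only two compounds carry a number here, and compound 2 holds the lower of the two figures, yet its gap to compound 1 lies within the usual scatter, so the two cannot be ranked against each other. Compound 3 `N=C(NCCCc1c[nH]cn1)NCCC(c1cc(F)cc(F)c1)c1ccccn1` has not been measured. It differs from compound 2 in one place: 3,5-difluorophenyl in place of 4-bromophenyl on a saturated chain carbon bound to an aromatic carbon and a saturated chain carbon. Among the compounds with values here, no step between measured compounds in this assay is available to guide the size of this change, and the two figures in hand show that a different substituted phenyl at this position has left the value essentially unchanged. The step is therefore expected to be a number 0.07 log units lower from compound 2 to compound 3 (within the scatter), with no direction beyond the scatter. Compound 3 is estimated at 6.9, with a range from 6.3 to 7.5.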

Compound 3, negative logarithm of the half-maximal effective concentration: 7.91
For compound 3 the middle estimate is 1.01 log units below the measured one, outside the stated range (above it).
By their numbers in this assay, from the lowest: compounds 2 and 1 (each within the scatter of the next); then compound 3.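

In this assay, 3,5-difluorophenyl in place of 4-bromophenyl gives a number 0.94 log units higher from compound 2 to compound 3 (beyond the scatter), so this position, which had seemed flat from compound 1 and compound 2 alone, does respond to a change of the aryl group. The two groups have the same counts of hydrogen-bond donors and acceptors and carry no net charge, so those counts do not separate compound 2 from compound 3. Nothing available bears on why the number rises.

The compounds shown leave open whether the step belongs to the fluorine atoms themselves or to the pattern of substitution on the ring, since bromine and fluorine differ here in both kind and number. Going by these compounds, it also remains open whether chlorine atoms or methoxy groups in place of the two fluorines would keep the higher number.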